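This account rests on a few compounds, and the source may have more. Where it says the series, first, only, none or still open, it means among the compounds named here.

Working notes on the series.

Compound 1 `O=C1NC(c2ccccc2)CN1S(=O)(=O)c1ccccc1` gives 116000 nM in a functional assay on SK-MEL-2 cells (Homo sapiens) for cytotoxicity; a higher number here means a weaker inhibitor, a lower number a stronger inhibitor. Compound 2 `O=C1NC(c2ccccc2)CN1S(=O)(=O)c1ccc(Cl)cc1` carries the change (chloro in place of hydrogen on an aromatic carbon), and compound 2 gives 1430 nM in this assay; the step is an 81-fold lower number from compound 1 to compound 2 (1.91 log units; beyond the scatter). Compound 3 `Cc1ccc(C2CNC(=O)N2S(=O)(=O)c2ccccc2)cc1` gives 144000 nM in this assay; the difference between the core of compound 3 and the core of compound 1 is not broken down here. Compound 4 `Cc1ccc(C2CNC(=O)N2S(=O)(=O)c2ccc(Cl)cc2)cc1` is not yet measured; it differs from compound 3 by chloro in place of hydrogen on an aromatic carbon, the same change that compound 1 and compound 2 show, made on the core of compound 3. Because the earlier step was an 81-fold lower number from compound 1 to compound 2 (1.91 log units; beyond the scatter), a step of similar direction and size is expected for compound 4, estimated as a 48-fold lower number from compound 3 to compound 4 (1.68 log units; beyond the scatter). Compound 4 is therefore expected to give about 3000 nM, between 900 nM and 15000 nM.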

Compound 4, half-maximal inhibitory concentration: 255000 nM
The estimate for compound 4 lay 85-fold (1.93 log units) below the measured number; measured number above the stated range.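

On the core of compound 3, the change from phenyl to 4-chlorophenyl gives a 1.8-fold higher number from compound 3 to compound 4 (0.25 log units; within the scatter) in this assay, so the large step seen on the core of compound 1 does not carry over to this second core. The two steps differ, and the outcome of this change depends on the core it is made on, at least for these two pairs: the same change on two cores in this assay, an 81-fold lower number (1.91 log units; beyond the scatter) from compound 1 to compound 2 and a 1.8-fold higher number (0.25 log units; within the scatter) from compound 3 to compound 4, 140-fold (2.16 log units) apart, beyond the scatter of two such steps

This rests on two pairs only and does not show what in the core of compound 3 accounts for the difference, nor how the change behaves on any further core. Open, going by these compounds, is whether bromo, methoxy or an amine in place of the chloro would behave differently on the two cores. Also open, on these data alone, is whether a carboxylic acid on the shared core would alter either step.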